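Swapping bromo for methyl on a fluorinated analogue

This account rests on a few compounds, and the source may have more. Where it says the series, first, only, none or still open, it means among the compounds named here.

Compound 1 `O=C(Nc1ccc(Oc2ccnc3[nH]ccc23)cc1)c1cc(-c2ccc(Br)cc2)ncn1` is the starting point. In a functional assay on MCF7 cells (Homo sapiens) for cytotoxicity, read by MTT assay, with a stated time of 72 h (on this read-out higher numbers stand for weaker inhibition and lower numbers for stronger inhibition), compound 1 gives 3840 nM. Compound 2 `Cc1ccc(-c2cc(C(=O)Nc3ccc(Oc4ccnc5[nH]ccc45)cc3)ncn2)cc1` carries the change (methyl in place of bromo on an aromatic carbon), and in this assay compound 2 gives 1620 nM; the step of a 2.4-fold lower number from compound 1 to compound 2 (0.37 log units; beyond the scatter) is modest but clear. Compound 3 `O=C(Nc1ccc(Oc2ccnc3[nH]ccc23)c(F)c1)c1cc(-c2ccc(Br)cc2)ncn1` differs from compound 1 by fluoro in place of hydrogen on an aromatic carbon, and in this assay compound 3 gives 10300 nM, the step being a 2.7-fold higher number from compound 1 to compound 3 (0.43 log units; beyond the scatter). Compound 4 `Cc1ccc(-c2cc(C(=O)Nc3ccc(Oc4ccnc5[nH]ccc45)c(F)c3)ncn2)cc1` has not yet been tested. It differs from compound 3 by methyl in place of bromo on an aromatic carbon, the same change as seen between the first two compounds, at the same place. On this basis the expected step is a 2.4-fold lower number from compound 3 to compound 4 (0.38 log units; beyond the scatter), beside the measured 2.4-fold lower number from compound 1 to compound 2 (0.37 log units; beyond the scatter). Going by the values given here, only one such step is known. Compound 4 is therefore estimated at 4300 nM in this assay, within a range from 2000 nM to 9500 nM.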

Compound 4, half-maximal inhibitory concentration: 6730 nM
Compound 4: middle estimate off by 1.6-fold (0.19 log units), on the low side; low and high end bracket the measured number.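

In this assay, swapping bromo for methyl on the core carrying fluoro gives a 1.5-fold lower number from compound 3 to compound 4 (0.18 log units; within the scatter), and this step does not differ from the earlier one: the same change on two cores in this assay, a 2.4-fold lower number (0.37 log units; beyond the scatter) from compound 1 to compound 2 and a 1.5-fold lower number (0.18 log units; within the scatter) from compound 3 to compound 4, 1.5-fold (0.19 log units) apart, within the scatter of two such steps. Adding fluoro gives a 4.2-fold higher number from compound 2 to compound 4 (0.62 log units; beyond the scatter), which also agrees with its earlier step: the same change on two cores in this assay, a 2.7-fold higher number (0.43 log units; beyond the scatter) from compound 1 to compound 3 and a 4.2-fold higher number (0.62 log units; beyond the scatter) from compound 2 to compound 4, 1.5-fold (0.19 log units) apart, within the scatter of two such steps. Going by these compounds alone, both changes therefore carried from one core to the other within the scatter, but this rests on only two pairs per change, and the step to compound 4 alone does not show that methyl and bromo differ on the core carrying fluoro.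

As far as these compounds go, it remains open whether other groups in place of bromo, such as chloro, methoxy or an amine, would carry over in the same way.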